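A few compounds are considered here, and "the series" means these few. Any claim that something is new, unique, unknown or untested is made for them only; others in the source may bear on it.

Compound 1 `CC(C)C(Cc1ncc[nH]1)c1ccc(-c2ccc3cccc(F)c3c2)[nH]c1=O` is the stronger of the two compounds measured in a functional assay on CHO cells for antagonist activity at prostaglandin E2 receptor EP3 subtype (Homo sapiens), read by cAMP accumulation; on this read-out higher numbers stand for weaker inhibition and lower numbers for stronger inhibition: compound 1 gives 76 nM, while compound 2 `CC(C)C(O)(C(=O)O)c1ccc(-c2ccc3ccccc3c2)[nH]c1=O` gives 1580 nM in this assay, a gap well beyond the usual scatter. Compound 3 `CC(C)C(c1cnc(N)s1)c1ccc(-c2ccc3cccc(F)c3c2)[nH]c1=O` is compound 1 altered in a single place: 2-amino-1,3-thiazol-5-yl in place of (1H-imidazol-2-yl)methyl on a saturated chain carbon bound to an aromatic carbon and a saturated chain carbon. Among the compounds with values here, no measured pair shows this exchange, so the outlook rests on compound 1 alone. A modest shift toward a higher number, near the edge of the scatter, is expected in this assay, and compound 3 is therefore estimated at 150 nM, within 40 nM to 600 nM, a step of a 2.0-fold higher number from compound 1 to compound 3 (0.30 log units; within the scatter).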

Compound 3, half-maximal inhibitory concentration: 39 nM
Compound 3: the middle estimate sits 3.8-fold (0.59 log units) above what was measured; the whole stated range lies above it.
By their numbers in this assay, from the lowest: compounds 3 and 1 (each within the scatter of the next); then compound 2.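

Within this assay the exchange of (1H-imidazol-2-yl)methyl for 2-amino-1,3-thiazol-5-yl gives a 1.9-fold lower number from compound 1 to compound 3 (0.29 log units; within the scatter). This saturated chain carbon therefore carries either of two different five-membered aromatic rings, one of them holding sulfur, with no change beyond the scatter. Nothing measured here explains why the two groups read alike. Still open, on these data alone, is whether the amino group on the thiazole matters, which a thiazole without it would test. A six-membered pyridine ring at this place also remains untested among the compounds shown.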